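A few compounds are considered here, and "the series" means these few. Any claim that something is new, unique, unknown or untested is made for them only; others in the source may bear on it.

Measured so far in a functional assay on DU-145 cells (Homo sapiens) for inhibition, read by trypan blue exclusion, with a stated time of 72 h; on this read-out higher numbers stand for weaker inhibition and lower numbers for stronger inhibition:
compound 1 `Cn1c(=O)c(S(=O)(=O)c2ccc(C(=O)O)cc2)cc2cnc(Nc3ccc4[nH]ccc4c3)nc21` — 10000 nM
compound 2 `CCCn1c(=O)c(S(=O)(=O)c2ccc(F)cc2F)cc2cnc(Nc3ccc4[nH]ccc4c3)nc21` — 1000 nM
compound 3 `COc1ccc(S(=O)(=O)c2cc3cnc(Nc4ccc5[nH]ccc5c4)nc3n(C)c2=O)cc1` — 500 nM

Compound 2 stands second highest of the three numbers: compound 3 gives a value within the scatter of it, compound 1 a value beyond the scatter and higher. Among the measured compounds shown here, the only step measured, a 20-fold lower number from compound 1 to compound 3 (1.30 log units; beyond the scatter), concerns a group on an aromatic carbon and says nothing about the chain on the aromatic nitrogen. Compound 4 `CCn1c(=O)c(S(=O)(=O)c2ccc(F)cc2F)cc2cnc(Nc3ccc4[nH]ccc4c3)nc21` differs from compound 2 in hydrogen in place of methyl on a saturated chain carbon, two bonds along the chain from an aromatic nitrogen, propyl to ethyl. For the measured compounds named here, no measured pair varies this chain, so there is no ground for a step in either direction; the expectation is none beyond the scatter. Compound 4 is therefore estimated at 1000 nM (range 400 nM to 2500 nM), the expected step being no change at the digits printed from compound 2 to compound 4 (within the scatter).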

Compound 4, half-maximal inhibitory concentration: 750 nM
Compound 4: middle estimate off by 1.3-fold (0.12 log units), on the high side; the range from low to high includes it.
By their numbers in this assay, from the lowest: compounds 3, 4 and 2 (each within the scatter of the next); then compound 1.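

Hydrogen in place of methyl on a saturated chain carbon, two bonds along the chain from an aromatic nitrogen, gives a 1.3-fold lower number from compound 2 to compound 4 (0.12 log units; within the scatter) in this assay. Among the compounds shown here, this is the first reading on this chain, and going from propyl to ethyl leaves the number within the scatter, whereas the only earlier step concerned a group on an aromatic carbon. No measurement on hand offers an explanation for this result.

Still open, going by these compounds, is whether a longer chain, such as butyl, would behave the same way. A chain ending in an amine or a carboxylic acid also remains untested at this position in the compounds shown.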